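A few compounds are considered here, and "the series" means these few. Any claim that something is new, unique, unknown or untested is made for them only; others in the source may bear on it.

Measured in a functional assay on HCT-116 cells (Homo sapiens) for antiproliferative activity, read by sulforhodamine B assay, with a stated time of 72 h; a lower number here means a stronger inhibitor, a higher number a weaker inhibitor:
Compound 1 `OC[C@H]1O[C@@H](n2cnc3c(N4CCN(C5CCCCC5)CC4)ncnc32)[C@H](O)[C@@H]1O`: > 100000 nM, a limit and not a number
Compound 2 `OC[C@H]1O[C@@H](n2cnc3c(N4CCN(c5ncccn5)CC4)ncnc32)[C@H](O)[C@@H]1O`: > 100000 nM, a limit and not a number
Compound 3 `Cc1ccc(N2CCN(c3ncnc4c3ncn4[C@@H]3O[C@H](CO)[C@@H](O)[C@H]3O)CC2)cc1`: 70000 nM

Compound 2 sits at the limit of > 100000 nM in this assay, at which 2 of the 3 values shown sit. Compound 4 `Nc1nc(N2CCN(c3ncccn3)CC2)c2ncn([C@@H]3O[C@H](CO)[C@@H](O)[C@H]3O)c2n1` differs from compound 2 at one place: amino in place of hydrogen on an aromatic carbon. This puts amino in place of hydrogen on an aromatic carbon, between two ring nitrogen atoms. Going by the values given here, no measured step touches that place. The steps available change only the group on the amine nitrogen in a ring. One is an at least 1.4-fold lower number from compound 2 to compound 3 (0.15 log units; that floor lies within the scatter), and another is an at least 1.4-fold lower number from compound 1 to compound 3 (0.15 log units; that floor lies within the scatter). A third is a step that the two limits leave unreadable from compound 1 to compound 2. As far as these compounds go, with so little to go on, no step beyond the scatter is expected in this assay, and the direction stays open. The expected result is a number no higher from compound 2 to compound 4 (the limit leaves the size open). Compound 4 is estimated at 100000 nM, within an expected range of 40000 nM to 200000 nM.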

Compound 4, half-maximal inhibitory concentration: "not active" (no number reported)
For compound 4 the study gives words and no number; there is nothing to compare the estimate with.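

Compound 4 is reported in words without a number and compound 2 only as a limit, and no new step can be read between them. The compounds shown leave open what amino in place of hydrogen on an aromatic carbon does in this assay.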